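Quinazoline urea series: aryl to phenylethyl swap at the amino nitrogen

The compounds below may be only part of what the source reports. "The series", "measured", "known", "first", "only" and "open" are said of these compounds alone.

Compound 2 `CN1CCN(Cc2ccc(NC(=O)Nc3ccc4ncnc(Nc5cccc(C(F)(F)F)c5)c4c3)cc2)CC1` gives 2410 nM in a functional assay on A-431 cells (Homo sapiens) for antiproliferative activity, read by MTT assay, with a stated time of 72 h (a higher number here means a weaker inhibitor, a lower number a stronger inhibitor), the highest of the two numbers shown, while compound 1 `COc1ccc(Nc2ncnc3ccc(NC(=O)Nc4ccc(CN5CCN(C)CC5)cc4)cc23)cc1Cl` gives 2010 nM; the step of a 1.2-fold higher number from compound 1 to compound 2 (0.08 log units; within the scatter) lies within the scatter. Compound 3 `C[C@@H](Nc1ncnc2ccc(NC(=O)Nc3ccc(CN4CCN(C)CC4)cc3)cc12)c1ccccc1` differs from compound 2 by 1-phenylethyl in place of 3-(trifluoromethyl)phenyl on a nitrogen on an aromatic ring. Within the data shown here, no measured step touches this kind of change; the single measured step replaces one aromatic group with another and tells nothing about an aliphatic substituent here. The step of a 1.2-fold higher number from compound 2 to compound 3 (0.10 log units; within the scatter) is therefore expected to be small, with direction uncertain. Compound 3 is estimated at 3000 nM, between 900 nM and 10000 nM.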

Compound 3, half-maximal inhibitory concentration: > 10000 nM
Compound 3 gave a limit, no number (the forecaster's own chance of this, stated with the estimate: 10%); middle value at least 3.3-fold (0.52 log units) away from the limit.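

Compound 3 gives a limit of the assay, not a number: the limit of > 10000 nM in this assay, at which 1 of the 3 values shown sits. The group on this nitrogen on an aromatic ring does matter: exchanging one aryl group for another stayed within the scatter, with a 1.2-fold higher number from compound 1 to compound 2 (0.08 log units; within the scatter), whereas 1-phenylethyl gives an at least 4.1-fold higher number from compound 2 to compound 3 (0.61 log units; beyond the scatter) and an at least 4.9-fold higher number from compound 1 to compound 3 (0.69 log units; beyond the scatter). Among these compounds, both aryl groups tolerated here are attached directly through their aromatic ring, and the change to 1-phenylethyl is the first to depart from that.

From the compounds shown here alone, how benzyl or the opposite enantiomer of 1-phenylethyl would read on this nitrogen remains open. So does whether substituents on the phenyl ring of 1-phenylethyl, such as chlorine or trifluoromethyl, would change the result.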